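Acetamide truncation of the pyrrolidinyl side chain

The source may hold more compounds than are shown below. What is called first, only, known or untested is meant among the compounds shown, and "the series" means these compounds.

In an ADME assay on MDBK cells (Bos taurus) for cytotoxicity, read by MTT assay, with a stated time of 96 h (on this read-out higher numbers stand for lower toxicity in this test and lower numbers for higher toxicity in this test), compound 1 `Nc1ccc(-c2nc3cc(Cl)c(Cl)cc3[nH]2)cc1` gives 7500 nM, compound 2 `O=C(CN1CCCC1)Nc1ccc(-c2nc3cc(Cl)c(Cl)cc3[nH]2)cc1` gives 16000 nM, and compound 3 `O=C(CN1CCCCC1)Nc1ccc(-c2nc3ccccc3[nH]2)cc1` gives 18000 nM. For the measured compounds named here, compound 2 thus holds the second highest of the three numbers: its value and that of compound 3 lie within the scatter of each other, while the single one-place step, a 2.1-fold higher number from compound 1 to compound 2 (0.33 log units; beyond the scatter), is modest but beyond the scatter. Compound 4 `CC(=O)Nc1ccc(-c2nc3cc(Cl)c(Cl)cc3[nH]2)cc1` keeps the amide of compound 2 but drops the ring: hydrogen in place of pyrrolidin-1-yl on a saturated chain carbon bound to a carbonyl carbon. Only a 2.1-fold higher number from compound 1 to compound 2 (0.33 log units; beyond the scatter) bears on this, as compound 4 sits between the two. Going by the values given here, the number is therefore expected to fall no further than that step, most likely a 1.5-fold lower number from compound 2 to compound 4 (0.16 log units; within the scatter), within the scatter. Compound 4 is estimated at 11000 nM, ranging from 5000 nM to 25000 nM.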

Compound 4, half-maximal cytotoxic concentration: 58000 nM
Estimate against measurement, compound 4: 5.3-fold (0.72 log units) below; the measured number lies above the stated range.
By their numbers in this assay, from the lowest: compound 1; then compounds 2 and 3 (each within the scatter of the next); then compound 4.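

In this assay, the step of a 3.6-fold higher number from compound 2 to compound 4 (0.56 log units; beyond the scatter) shows that pyrrolidin-1-yl on a saturated chain carbon bound to a carbonyl carbon goes with a lower number than hydrogen there. Acetyl in place of hydrogen on a nitrogen on an aromatic ring gives a 7.7-fold higher number from compound 1 to compound 4 (0.89 log units; beyond the scatter), so the amide does not need the ring to raise the number. No data on hand account for this change.
As far as these compounds go, whether morpholin-4-yl or a dimethylamino group at this place would stay nearer compound 2 or compound 4 remains open. From the compounds shown here alone, a longer chain in place of methyl remains equally open.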